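Compound 2 to compound 3: 4-methoxyphenyl on the series

The compounds below may be only part of what the source reports. "The series", "measured", "known", "first", "only" and "open" are said of these compounds alone.

Measured so far in an ADME assay on HCT-116 cells (Homo sapiens) for cytotoxicity, read by CellTiter-Glo, with a stated time of 72 h; on this read-out higher numbers stand for weaker inhibition and lower numbers for stronger inhibition (both values are limits):
- compound 1 `COc1ccccc1-c1ccc(S(=O)(=O)N2CCC(N3CCC(C)CC3)CC2)cc1` gives > 5000 nM 
- compound 2 `CC1CCN(C2CCN(S(=O)(=O)c3ccc(OC(F)(F)F)cc3)CC2)CC1` gives > 5000 nM 

For the measured compounds named here, compound 2 has only a limit to its name, > 5000 nM in this assay as its single reading. Across the series the data amount to the limit of > 5000 nM in this assay, at which 2 of the 2 values shown sit, and nothing more.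

Compound 3 `COc1ccc(-c2ccc(S(=O)(=O)N3CCC(N4CCC(C)CC4)CC3)cc2)cc1` carries 4-methoxyphenyl in place of trifluoromethoxy on an aromatic carbon, para to a large group (4-methoxyphenyl in place of trifluoromethoxy on an aromatic carbon). Going by the values given here, the one measured step at this place is a step that the two limits leave unreadable from compound 1 to compound 2 and it offers no size to carry over. Compound 1 holds 2-methoxyphenyl at this place, and its > 5000 nM is likewise a limit.

With compound 1 at > 5000 nM as the closest aryl case, no step beyond the scatter is expected in this assay and a further limit is the likeliest report. The expected step that the limit leaves unreadable from compound 2 to compound 3 is an estimate resting on limits alone. The estimated value for compound 3 is 6000 nM with an expected range from 2500 nM to 15000 nM in this estimate.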

Compound 3, half-maximal inhibitory concentration: > 5000 nM
Compound 3 ended at the assay's limit; the forecaster's own chance of this, stated with the estimate: 75%; the middle value does not contradict the limit.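

No step can be read among compound 1, compound 2 and compound 3 in this assay, because each value is a limit: the limit of > 5000 nM in this assay, at which 3 of the 3 values shown sit.

The compounds shown leave open whether any group at this place on the shared core gives a readable value in this assay, and how large a step between trifluoromethoxy, 2-methoxyphenyl and 4-methoxyphenyl would be.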